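The source may report more compounds than this note shows. Statements on the series, on what has been measured and on what is new or still open speak of the compounds shown alone.

Working notes on the series. Compound 1 `COc1ccc(/C(Cl)=C/C=C(\C#N)C(=O)c2c(C)[nH]c3ccccc23)cc1`, compound 2 `COc1ccc(/C(Cl)=C/C=C(\C#N)C(=O)c2c[nH]c3ccccc23)cc1` and compound 3 `COc1ccc(/C(Cl)=C/C=C(\C#N)C(=O)c2c[nH]c3ccccc23)cc1OC` share one core and differ only at single positions. In a functional assay on MCF7 cells (Homo sapiens) for cytotoxicity, read by sulforhodamine B assay, with a stated time of 48 h (on this read-out lower numbers stand for stronger inhibition of growth and higher numbers for weaker inhibition of growth), compound 1 gives > 100000 nM, which is a limit of the assay and not a number. Compound 2 likewise sits at the limit > 100000 nM. Compound 3 also stands only at the limit > 100000 nM, so its position among the values shown is a limit alone. The step that the two limits leave unreadable from compound 1 to compound 2 and the step that the two limits leave unreadable from compound 2 to compound 3 carry no readable size because of the limit of > 100000 nM in this assay, at which 3 of the 3 values shown sit. Compound 4 `COc1ccc(/C(Cl)=C/C=C(\C#N)C(=O)c2c(C)[nH]c3ccccc23)cc1OC` differs from compound 3 by methyl in place of hydrogen on an aromatic carbon. Within the data shown here, the only comparable measured change is the first of those two steps, and its size is not readable, so no direction can be drawn from it. Compound 4 is therefore expected to remain at the limit, with an expected step that the limit leaves unreadable from compound 3 to compound 4 of no readable size. The estimate for compound 4 is 150000 nM, with a range from 50000 nM to 500000 nM.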

Compound 4, concentration for total growth inhibition: 93000 nM
Estimate against measurement, compound 4: 1.6-fold (0.21 log units) above; measured number inside the range.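

In this assay, among these compounds, the pairing of the methyl on the aromatic carbon next to the ring nitrogen with the second methoxy gives the first number, in compound 4 at 93000 nM. Adding the methyl gives an at least 1.0-fold lower number from compound 3 to compound 4 (0.03 log units; that floor lies within the scatter), and adding the methoxy gives an at least 1.0-fold lower number from compound 1 to compound 4 (0.03 log units; that floor lies within the scatter). Both are floors only, and the true size of neither step can be read, because the other compounds all stand at a limit: the limit of > 100000 nM in this assay, at which 3 of the 4 values shown sit.

Going by these compounds, how far each group contributes remains open. On these data alone, what a longer chain or an amine would give in place of the methyl also remains open.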